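Swapping the thiophene-methyl for a pyridine on the nitrogen

The source may hold more compounds than are shown below. What is called first, only, known or untested is meant among the compounds shown, and "the series" means these compounds.

Three compounds sharing one core were measured in an assay (strain Wistar) for inhibition of Hormone-sensitive lipase (Rattus norvegicus), read by spectrophotometry; on this read-out lower numbers stand for stronger inhibition and higher numbers for weaker inhibition. Compound 1 `Cc1c(C2CCOCC2)c(=O)on1C(=O)N1CCCCC1` gives 71 nM. Compound 2 `Cc1c(C(C)C)c(=O)on1C(=O)N(C)Cc1ccc(F)cc1` gives 111 nM. Compound 3 `Cc1c(C(C)C)c(=O)on1C(=O)N(C)Cc1cccs1` gives 2 nM, the lowest of the three numbers, and the gap to the others is well beyond the scatter; a 56-fold lower number from compound 2 to compound 3 (1.74 log units; beyond the scatter). Compound 4 `Cc1c(C(C)C)c(=O)on1C(=O)N(C)c1ccccn1` differs from compound 3 in one place: pyridin-2-yl in place of (thiophen-2-yl)methyl on an amide-type nitrogen. Among the measured compounds shown here, no measured step removes the chain carbon on this nitrogen, so only the large step from compound 2 to compound 3 bears on it, showing that the group on this nitrogen can shift this assay strongly. A step toward weaker inhibition is expected, a 15-fold higher number from compound 3 to compound 4 (1.18 log units; beyond the scatter). Compound 4 is therefore estimated at 30 nM, between 4 nM and 250 nM.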

Compound 4, half-maximal inhibitory concentration: 240 nM
Compound 4: middle estimate off by 8.0-fold (0.90 log units), on the low side; measured number inside the range.
By their numbers in this assay, from the lowest: compound 3; then compounds 1 and 2 (each within the scatter of the next); then compound 4.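

The swap of (thiophen-2-yl)methyl for pyridin-2-yl gives a 120-fold higher number from compound 3 to compound 4 (2.08 log units; beyond the scatter) in this assay, a second large step on this amide-type nitrogen, this time toward weaker inhibition. The two groups have the same counts of heavy atoms, hydrogen-bond donors and hydrogen-bond acceptors, so those counts do not settle the number here. No measurement at hand accounts for this step.

Two things change at once, the chain carbon on the nitrogen and the ring, and the compounds shown do not separate them. A (pyridin-2-yl)methyl group on this nitrogen would keep the chain carbon and change only the ring.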